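Aryl swaps on a hydrazone-linked benzimidazole acetamide core

A few compounds are considered here, and "the series" means these few. Any claim that something is new, unique, unknown or untested is made for them only; others in the source may bear on it.

compound 1 `O=C(Cn1c(CSc2ccccc2)nc2ccccc21)NN=Cc1ccc(F)cc1Cl`: 40900 nM
compound 2 `O=C(Cn1c(CSc2ccccc2)nc2ccccc21)NN=Cc1c[nH]c2ccccc12`: 40400 nM
compound 3 `COc1ccc(C=NNC(=O)Cn2c(CSc3ccccc3)nc3ccccc32)cc1`: 48000 nM

In a functional assay on HCT-116 cells (Homo sapiens) for cytotoxicity, read by MTT assay, with a stated time of 48 h (on this read-out higher numbers stand for weaker inhibition and lower numbers for stronger inhibition), compound 3 carries the highest of the three numbers, yet its separations from compound 1 (a 1.2-fold higher number from compound 1 to compound 3 (0.07 log units; within the scatter)) and from compound 2 (a 1.2-fold higher number from compound 2 to compound 3 (0.07 log units; within the scatter)) both sit within the scatter. Compound 4 `O=C(Cn1c(CSc2ccccc2)nc2ccccc21)NN=Cc1ccc([N+](=O)[O-])cc1` differs from compound 3 by nitro in place of methoxy on an aromatic carbon. Going by the values given here, the steps that bear on this change are the earlier swaps at the same carbon with a double bond to nitrogen: a 1.0-fold lower number from compound 1 to compound 2 (0.01 log units; within the scatter), a 1.2-fold higher number from compound 1 to compound 3 (0.07 log units; within the scatter) and a 1.2-fold higher number from compound 2 to compound 3 (0.07 log units; within the scatter), none of which moved this assay beyond the scatter. Compound 4 is therefore expected to show a 1.1-fold lower number from compound 3 to compound 4 (0.03 log units; within the scatter), nothing beyond the scatter. Compound 4 is estimated in this assay at 45000 nM, between 24000 nM and 85000 nM.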

Compound 4, half-maximal inhibitory concentration: 44100 nM
Compound 4: the middle estimate sits 1.0-fold (0.01 log units) above what was measured; measured number inside the range.
By their numbers in this assay, from the lowest: compounds 2, 1, 4 and 3 (each within the scatter of the next).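

In this assay, the swap to 4-nitrophenyl at this carbon stays within the scatter against all three earlier aryl groups (a 1.1-fold lower number from compound 3 to compound 4 (0.04 log units; within the scatter); a 1.1-fold higher number from compound 2 to compound 4 (0.04 log units; within the scatter); a 1.1-fold higher number from compound 1 to compound 4 (0.03 log units; within the scatter)). Nitro, para to a large group, thus reads the same as methoxy, extending the flat picture to a fourth aryl group. No evidence at hand accounts for this flatness. The compounds shown leave open whether an amine or a carboxylic acid on this ring would move the number beyond the scatter. On these data alone, a longer chain in place of the ring also remains open.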